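The source may report more compounds than this note shows. Statements on the series, on what has been measured and on what is new or still open speak of the compounds shown alone.

Measured so far:
compound 1 `O=S(=O)(c1ccccc1)n1c(-c2cn(-c3ccccc3)nc2-c2ccc(F)cc2)nc2ccccc21`: 720 nM
compound 2 `O=S(=O)(c1ccc(F)cc1)n1c(-c2cn(-c3ccccc3)nc2-c2ccc(F)cc2)nc2ccccc21`: 3520 nM
compound 3 `O=S(=O)(c1ccc(C(F)(F)F)cc1)n1c(-c2cn(-c3ccccc3)nc2-c2ccc(F)cc2)nc2ccccc21`: 1680 nM

All three values come from a functional assay on HepG2 cells (Homo sapiens) for antiproliferative activity, read by MTT assay, with a stated time of 24 h; a higher number here means a weaker inhibitor, a lower number a stronger inhibitor. Compound 1 gives the lowest of the three numbers, with compound 3 nearest to it. The step from compound 1 to compound 2 is a 4.9-fold higher number from compound 1 to compound 2 (0.69 log units; beyond the scatter), that from compound 1 to compound 3 is a 2.3-fold higher number from compound 1 to compound 3 (0.37 log units; beyond the scatter), and between the two substituted analogues the step is a 2.1-fold lower number from compound 2 to compound 3 (0.32 log units; beyond the scatter), which belongs to the change (trifluoromethyl in place of fluoro on an aromatic carbon).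

Compound 4 `O=S(=O)(c1ccccc1)n1c(-c2cn(-c3ccccc3)nc2-c2ccc(C(F)(F)F)cc2)nc2ccccc21` is not yet measured. It differs from compound 1 by trifluoromethyl in place of fluoro on an aromatic carbon. Going by the values given here, this is the same kind of change as the one from compound 2 to compound 3, and the description of the place reads the same in both cases. The two starting cores are not the same, however: compound 1 differs from compound 2 by hydrogen in place of fluoro on an aromatic carbon, so the change is made on a different ring in a different setting.

Among the compounds with values here, only one measured instance of this change exists, and it sits on the other ring, so the expectation rests on a single pair. Compound 4 is expected to follow the direction of that pair, with the step from compound 1 estimated as a 1.6-fold lower number from compound 1 to compound 4 (0.20 log units; within the scatter), because compound 2 to compound 3 gave a 2.1-fold lower number from compound 2 to compound 3 (0.32 log units; beyond the scatter). With wide allowance for the different position, compound 4 is estimated at 450 nM in this assay, between 150 nM and 1400 nM.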

Compound 4, half-maximal inhibitory concentration: 590 nM
Compound 4: the middle estimate sits 1.3-fold (0.12 log units) below what was measured; measured number inside the range.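

In this assay, going by these compounds alone, the change from 4-fluorophenyl to 4-(trifluoromethyl)phenyl on the core of compound 1 gives a 1.2-fold lower number from compound 1 to compound 4 (0.09 log units; within the scatter), so at this place the change produces no step that can be separated from repeat-measurement noise. Set beside the only other instance of this change, on a different ring and a different core, the two steps cannot be told apart: the same change on two cores in this assay, a 2.1-fold lower number (0.32 log units; beyond the scatter) from compound 2 to compound 3 and a 1.2-fold lower number (0.09 log units; within the scatter) from compound 1 to compound 4, 1.7-fold (0.23 log units) apart, within the scatter of two such steps. This shows that the two pairs do not disagree, but it does not show that the change carries a fixed effect from one core to another, since the step is beyond the scatter in one pair and within it in the other, and two pairs that also differ in the ring carrying the change cannot separate the effect of the core from that of the ring.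

Still open, from the compounds shown here alone, is how an amine, a carboxylic acid or a nitrile would read in place of fluoro or trifluoromethyl at this place on the ring. Also open, going by these compounds, is whether the steps seen on each ring would add up in an analogue carrying trifluoromethyl on both rings, and whether any of these steps would hold outside this assay.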